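The compounds below may be only part of what the source reports. "The series", "measured", "known", "first", "only" and "open" are said of these compounds alone.

Notes on the series. Two members of the series have numbers in an assay on cells with melanin-concentrating hormone receptor 1 (Homo sapiens) as the target, read by radioligand binding (a lower number here means a stronger inhibitor, a higher number a weaker inhibitor), so far. Compound 1 `CCC(CC)C(C)Oc1cccc2ccc(N)nc12` carries a branched alkyl ether on its core; in this assay compound 1 gives 191 nM. Compound 2 `Nc1ccc2cccc(OCC3CC3)c2n1` carries a cyclopropylmethyl ether in the same position. For compound 2 this assay returns only a limit, > 2000 nM, so compound 2 stands at the weak end of what has been measured, and how far beyond the limit it lies is not known; the limit of > 2000 nM in this assay, at which 1 of the 2 values shown sits, marks where it sits. Within the data shown here, no step between the two measured compounds can be computed, since one of the two values is a limit.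

Compound 3 `CC(C)C(C)Oc1cccc2ccc(N)nc12` is not yet measured. It differs from compound 2 by 1,2-dimethylpropyl in place of cyclopropylmethyl on an oxygen on an aromatic ring. The step from compound 2 is expected to run toward stronger inhibition and beyond the scatter, an at least 5.0-fold lower number from compound 2 to compound 3 (0.69 log units; beyond the scatter), because compound 1 with its branched alkyl ether gives 191 nM. For compound 3 the estimate in this assay is 400 nM, with a range from 120 nM to 1500 nM.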

Compound 3, half-maximal inhibitory concentration: 199 nM
Estimate against measurement, compound 3: 2.0-fold (0.30 log units) above; the range from low to high includes it.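

In this assay, among these compounds, 1,2-dimethylpropyl in place of cyclopropylmethyl on an oxygen on an aromatic ring gives an at least 10-fold lower number from compound 2 to compound 3 (1.00 log units; beyond the scatter), the first step that can be read at this place, and its size is known only as a bound. The value of compound 2 is a limit of the assay and not a number: the limit of > 2000 nM in this assay, at which 1 of the 3 values shown sits. Isopropyl in place of pentan-3-yl on a saturated chain carbon bound to an oxygen on an aromatic ring and a saturated chain carbon gives a 1.0-fold higher number from compound 1 to compound 3 (0.02 log units; within the scatter), so the two branched alkyl ethers cannot be told apart in this assay, and this exchange within the branched group leaves the reading where it was.

The step away from cyclopropylmethyl removes a three-membered ring and brings in a branched open chain at once, and the compounds shown do not separate these two differences. Also open, as far as these compounds go, is how an unbranched chain such as n-pentyl, or an ether group carrying an amine or a carboxylic acid, would read in this assay.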